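The source may report more compounds than this note shows. Statements on the series, on what has been measured and on what is new or still open speak of the compounds shown alone.

In an ADME assay on cells (spleen, Mus musculus, strain C57BL/6) for inhibition, read by flow cytometry and propidium iodide staining, with a stated time of 24 h, at 37 degrees C (a lower number here means that less compound is needed, a higher number that more compound is needed for the effect), compound 1 `O=C(Cn1cc(CO)nn1)NCc1ccccc1` gives 490 uM. Compound 2 `O=C(Cn1nncc1CO)NCc1ccccc1` gives > 2000 uM, which is a limit of the assay and not a number. Compound 3 `O=C(Cn1nncc1-c1cccc([N+](=O)[O-])c1)NCc1ccccc1` has no single number at all, and its result reads "non-toxic" (no number reported). Its place on the scale can therefore be described only in words, and it offers no firm starting value.

The compound still to be tested is compound 4 `COc1cccc(-c2cnnn2CC(=O)NCc2ccccc2)c1`. The structural change is methoxy in place of nitro on an aromatic carbon, with methoxy in place of nitro on an aromatic carbon, meta to a large group. Among the measured compounds shown here, no measured pair here shows what such a swap does in this assay, so the expectation is for no step beyond the scatter, in either direction. That expectation leans on compound 3, reported as "non-toxic" (no number reported), and it means a high concentration should again be needed for any effect.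

For compound 4 the estimated value is 1200 uM, with an expected range from 300 uM to 2500 uM.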

Compound 4, concentration for half-maximal effect: > 2000 uM
Compound 4: a limit, no number; the forecaster's own chance of this, stated with the estimate: 55%; middle value at least 1.6-fold (0.22 log units) from the limit.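

In this assay compound 4 gives > 2000 uM, which is a limit and not a number. Among the compounds shown here, compound 2 also sits at a limit and compound 3 has no number, so no step to compound 4 can be read. From the compounds shown here alone, what remains open is the concentration at which compound 2, compound 3 or compound 4 would reach half-maximal effect.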